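The compounds below may be only part of what the source reports. "The series", "measured", "known", "first", "only" and "open" are said of these compounds alone.

Measured so far:
- compound 1 `COc1ccc(N2CCN(Cc3csc(N)c3C(=O)c3ccc(Cl)cc3)CC2)cc1`; in a functional assay on CHO cells with adenosine receptor A1 (Homo sapiens) as the target, read by cAMP accumulation and immunoassay, with a stated time of 6 min, tested at 10 uM (on this read-out lower numbers stand for a stronger effect and higher numbers for a weaker effect at the one concentration tested), compound 1 gives -52%
- compound 2 `Nc1scc(CN2CCN(c3ccncc3)CC2)c1C(=O)c1ccc(Cl)cc1`; in this assay compound 2 gives -15%

Compound 2 stands highest of the two numbers; its nearest neighbour is compound 1, separated by the step of a number 37 percentage points higher from compound 1 to compound 2 (beyond the scatter). Compound 3 `Nc1scc(CN2CCN(c3cccc(F)c3)CC2)c1C(=O)c1ccc(Cl)cc1` differs from compound 2 in one place: 3-fluorophenyl in place of pyridin-4-yl on an amine nitrogen in a ring. Going by the values given here, the only measured step that bears on this change is a number 37 percentage points higher from compound 1 to compound 2 (beyond the scatter), in which a six-membered aromatic ring of carbon only gave way to pyridin-4-yl and the number rose by a large amount. Among the compounds with values here, compound 3 brings a six-membered aromatic ring of carbon only back to that place, so the step in this assay is expected to run downward and to be sizeable, though the fluorine-bearing ring has no measured counterpart here. The expected step is a number 25 percentage points lower from compound 2 to compound 3 (beyond the scatter). Compound 3 is therefore estimated at -40%, within a range from -65% to -10%.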

Compound 3, a percentage reported as activity, at one concentration (the size of the read-out at that concentration, not a potency): -82%
The estimate for compound 3 lay 42 percentage points above the measured number, outside the stated range (below it).
By their numbers in this assay, from the lowest: compound 3; then compound 1; then compound 2.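

In this assay, replacing pyridin-4-yl with 3-fluorophenyl on the amine nitrogen in the ring gave a number 67 percentage points lower from compound 2 to compound 3 (beyond the scatter), showing that this position can carry the number well past the value of compound 1. The two rings of carbon only also differ clearly from each other: 3-fluorophenyl in place of 4-methoxyphenyl gave a number 30 percentage points lower from compound 1 to compound 3 (beyond the scatter), so a ring of carbon only at this position does not by itself fix the result. No measurement at hand accounts for either step.

The compounds shown leave open whether the fluorine itself or its place on the ring goes with the lower number. As far as these compounds go, how an unsubstituted phenyl, 4-fluorophenyl or benzyl group on the same nitrogen would read in this assay also remains open.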